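Swapping isobutylamino for diethylamino on a shared core

A few compounds are considered here, and "the series" means these few. Any claim that something is new, unique, unknown or untested is made for them only; others in the source may bear on it.

In a functional assay on A2780 cells (Homo sapiens) for antiproliferative activity, read by MTT assay, with a stated time of 72 h (a lower number here means a stronger inhibitor, a higher number a weaker inhibitor), compound 1 (`CC(C)NC(=N)NC(=N)Nc1ccc(C(F)(F)F)cc1`) gives 3200 nM and compound 2 (`CC(C)CNC(=N)NC(=N)Nc1ccc(C(F)(F)F)cc1`) gives 2100 nM and so stands level with it, within the scatter. Compound 3 (`CCN(CC)C(=N)NC(=N)Nc1ccc(C(F)(F)F)cc1`) has diethylamino in place of isobutylamino on a carbon with a double bond to nitrogen. Within the data shown here, only one measured step bears on this change. It is a 1.5-fold lower number from compound 1 to compound 2 (0.18 log units; within the scatter) for isobutyl in place of isopropyl on an amine nitrogen, and it stays within the scatter. That step swapped one chain for another, whereas diethylamino carries both its chains on the one nitrogen, so the guide is only partial. The step expected in this assay is small, an estimated 1.4-fold higher number from compound 2 to compound 3 (0.15 log units; within the scatter) that stays within the scatter. Compound 3 is expected to give about 3000 nM with an estimated range from 1200 nM to 7500 nM in this measurement.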

Compound 3, half-maximal inhibitory concentration: 3800 nM
Compound 3: the middle estimate sits 1.3-fold (0.10 log units) below what was measured; low and high end bracket the measured number.
By their numbers in this assay, from the lowest: compounds 2, 1 and 3 (each within the scatter of the next).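

In this assay, diethylamino in place of isobutylamino gives a 1.8-fold higher number from compound 2 to compound 3 (0.26 log units; within the scatter) and diethylamino in place of isopropylamino gives a 1.2-fold higher number from compound 1 to compound 3 (0.07 log units; within the scatter), so compounds 1, 2 and 3 all stand level. This is the first change shown that puts two chains on the one nitrogen and removes the hydrogen-bond donor that isobutylamino carries, and on this shared core neither difference separates compound 3 from compound 2 in this measurement. No supporting data bear on why the numbers stay level here.

What the compounds shown leave open is how a ring such as piperidine or morpholine, or a longer chain such as n-hexyl, would behave on this carbon with a double bond to nitrogen. They also leave open whether these groups would stand level with a nitrile in place of the trifluoromethyl group.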